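The compounds below may be only part of what the source reports. "The series", "measured", "known", "first", "only" and "open" are said of these compounds alone.

Working notes on the series.

The shared core carries a benzylidene that varies only in its ring substitution. Compound 1 `O=C1/C(=C/c2cccc(Br)c2)NS(=O)(=O)c2ccccc21` bears a bromo group; compound 2 `O=C1/C(=C/c2ccc(Cl)cc2Cl)NS(=O)(=O)c2ccccc21` a pair of chloro groups; compound 3 `O=C1/C(=C/c2c(F)cccc2F)NS(=O)(=O)c2ccccc21` a pair of fluoro groups. In an assay for inhibition of alkaline phosphatase, tissue-nonspecific isozyme (Homo sapiens), read by spectrophotometry, with stated times of 10 min and 20 min (a lower number here means a stronger inhibitor, a higher number a weaker inhibitor), compound 1 gives only a limit, > 200000 nM. Compound 2 likewise gives only a limit, > 200000 nM. Compound 3 gives a number, 1530 nM, and so stands apart from compounds 1 and 2. Among the compounds with values here, compound 1 thus sits at the ceiling of this assay together with compound 2, a point summarised by the limit of > 200000 nM in this assay, at which 2 of the 3 values shown sit, and no step between measured compounds can be computed from it.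

Compound 4 `O=C1/C(=C/c2cccc(O)c2)NS(=O)(=O)c2ccccc21` is the unmeasured partner of compound 1. The change is hydroxy in place of bromo on an aromatic carbon, so a hydroxy takes the place of the bromo on the aromatic carbon, meta to a large group; in other words 3-bromophenyl becomes 3-hydroxyphenyl. Within the data shown here, no measured step covers this exchange, and with compound 1 known only as a limit the size of the step cannot be anchored. A gain in this assay of moderate size is expected rather than none, with a wide margin, giving an expected step of an at least 3.3-fold lower number from compound 1 to compound 4 (0.52 log units; beyond the scatter). For compound 4 the estimate is 60000 nM, within 5000 nM to 200000 nM.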

Compound 4, half-maximal inhibitory concentration: 3570 nM
Compound 4: the middle estimate sits 17-fold (1.23 log units) above what was measured, outside the stated range (below it).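

In this assay, hydroxy in place of bromo on an aromatic carbon, meta to a large group, gives an at least 56-fold lower number from compound 1 to compound 4 (1.74 log units; beyond the scatter). Within the data shown here, the earlier compounds offered no pair differing in one place, so this is the first step that can be read, and it shows that a change in this one place is enough to take a compound from a limit to a measured number. The step sets only a minimum for the size of the change and not its full size, because the value at the bromo end is a limit of the assay and not a number: the limit of > 200000 nM in this assay, at which 2 of the 4 values shown sit.

Whether the gain belongs to hydroxy alone, or would also come with an amine, a methoxy or a carboxylic acid in the same place, stays open, as 3-hydroxyphenyl is the only replacement for 3-bromophenyl among the compounds shown. Also open, on these data alone, is whether the same exchange would carry over to a ring that already bears the chloro or fluoro groups of compound 2 or compound 3.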